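The compounds below may be only part of what the source reports. "The series", "measured", "known", "first", "only" and "open" are said of these compounds alone.

Of the compounds shown here, three have so far been measured in a functional assay on HT-29 cells (Homo sapiens) for antiproliferative activity, read by sulforhodamine B assay, with a stated time of 72 h; a higher number here means a weaker inhibitor, a lower number a stronger inhibitor. Compound 1 `NC(=S)N/N=C/c1cc2cccnc2s1` gives only a limit there, > 100000 nM, so no number stands against it. Compound 2 `S=C(N/N=C/c1ccc2ccccc2n1)Nc1cccc(Br)c1` gives 58900 nM in this assay, the higher of the two numbers obtained. Its nearest neighbour, compound 3 `CC(C)c1cccc(C(C)C)c1NC(=S)N/N=C/c1ccc2ccccc2n1`, gives 20700 nM in this assay, a lower number that lies beyond the usual scatter of such measurements.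

The step under consideration leads from compound 2 to compound 4 `S=C(N/N=C/c1ccc2ccccc2n1)Nc1ccccc1`, in which the 3-bromophenyl group becomes a plain phenyl group: hydrogen in place of bromo on an aromatic carbon. Among the compounds with values here, no step between two measured compounds is known that would show what this change does, so its size can only be expected. Compound 2 already stands high at 58900 nM, and with the bromo gone a modest shift toward a weaker inhibitor is expected, small enough that it may not clear the scatter. Compound 4 is expected to give about 80000 nM in this assay, between 30000 nM and 200000 nM. That expectation amounts to a step of a 1.4-fold higher number from compound 2 to compound 4 (0.13 log units; within the scatter), with a real chance that only a limit is returned.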

Compound 4, half-maximal inhibitory concentration: 17000 nM
Compound 4: the middle estimate sits 4.7-fold (0.67 log units) above what was measured, outside the stated range (below it).
By their numbers in this assay, from the lowest: compounds 4 and 3 (each within the scatter of the next); then compound 2. At a limit, above all of these: compound 1.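

In this assay, within the data shown here, hydrogen in place of bromo brings a 3.5-fold lower number from compound 2 to compound 4 (0.54 log units; beyond the scatter) and so gives the first direct reading of this change on the shared core. It shows that the 3-bromophenyl group is not needed for the activity seen here: the plain phenyl group gives the stronger inhibitor of the pair, and the bromo at this place, meta to a large group, goes with the weaker one. The data given hold no measured property that would account for this step.

The compounds shown leave open what a group other than bromo would do on this same aromatic carbon, for instance a methoxy group, an amine or a carboxylic acid. They also leave open whether a chloro or methyl group there would stand nearer compound 2 or compound 4.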